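The source may report more compounds than this note shows. Statements on the series, on what has been measured and on what is new or still open speak of the compounds shown alone.

Measured so far:
- compound 1 `C[C@@H](Nc1nccc(Cl)c1NC(=O)CC#N)c1ccc(-c2cccc(F)c2C#N)cc1`, which in an in vivo ADME assay on the whole organism (strain Sprague-Dawley) for metabolic stability, with Rattus norvegicus as the target, at a dose of 2 mg/kg by the intravenous route (a lower number here means that the compound disappears faster, a higher number that the compound lasts longer), gives 0.9 h
- compound 2 `C[C@@H](Nc1nccc(Cl)c1NC(=O)CC#N)c1ccc(-c2cccc(F)c2-c2nnn(C)n2)cc1`, which in this assay gives 7.8 h

Going by the values given here, compound 2 holds the higher of these two numbers; the only other compound, compound 1, sits an 8.7-fold higher number from compound 1 to compound 2 (0.94 log units; beyond the scatter) lower, a difference well beyond the scatter of the measurement. Compound 3 `Cc1nc(-c2c(F)cccc2-c2ccc([C@@H](C)Nc3nccc(Cl)c3NC(=O)CC#N)cc2)no1` is not yet measured. It differs from compound 2 in one place: 5-methyl-1,2,4-oxadiazol-3-yl in place of 2-methyl-2H-tetrazol-5-yl on an aromatic carbon. Among the compounds with values here, no measured pair shows this exact swap, so the expectation rests on indirect evidence. Within the data shown here, the one known step, an 8.7-fold higher number from compound 1 to compound 2 (0.94 log units; beyond the scatter), shows that a five-membered aromatic ring in this position rather than a nitrile goes with a much longer half-life. Compound 3 keeps a five-membered aromatic ring there, so compound 3 is expected to stay close to compound 2 rather than fall back to compound 1, with a mild drop allowed for. The expected step from compound 2 to compound 3 in this assay is a 1.6-fold lower number from compound 2 to compound 3 (0.19 log units; within the scatter). Compound 3 is therefore estimated at 5 h, with a range from 2 h to 12 h.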

Compound 3, half-life: 12.9 h
Estimate against measurement, compound 3: 2.6-fold (0.41 log units) below; measured number outside the range, above it.
By their numbers in this assay, from the lowest: compound 1; then compounds 2 and 3 (each within the scatter of the next).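

In this assay, the place on the aromatic carbon ortho to a fluoro group now holds two different five-membered aromatic rings. Replacing 2-methyl-2H-tetrazol-5-yl with 5-methyl-1,2,4-oxadiazol-3-yl gives (a 1.7-fold higher number from compound 2 to compound 3 (0.22 log units; within the scatter)), so these two rings, which differ in their hetero atoms, cannot be told apart in this measurement. The long half-life seen against the nitrile is therefore not tied to the tetrazole alone, since the oxadiazole also goes with a clear rise over the nitrile (a 14-fold higher number from compound 1 to compound 3 (1.16 log units; beyond the scatter)), and no compound shown goes against this, although nothing available explains the difference between these rings and the nitrile.

From the compounds shown here alone, all three compounds carry either a nitrile or a methyl-bearing ring at this place, so it remains open whether a ring without its methyl group, or an open group such as an amide or a carboxylic acid, would give a half-life nearer to that of compound 1 or that of compound 2. Going by these compounds, the fluoro group is also shared by all three, so whether these steps would hold with a hydrogen in its place remains unknown.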